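The compounds below may be only part of what the source reports. "The series", "measured", "known", "first", "only" and "open" are said of these compounds alone.

Measured compounds in the series:
compound 1 `C[C@H](c1ccc(-c2cc(F)ccc2-c2nc(=O)o[nH]2)cc1)N(CC1CC1)c1nc2c(C(=O)O)cccc2o1` with 2.3 nM
compound 2 `CCCCN(c1nc2c(NS(C)(=O)=O)cccc2o1)[C@H](C)c1ccc(-c2ccccc2-c2nnn[nH]2)cc1` with 14 nM
compound 3 `CCCCN(c1nc2c(C(=O)O)cccc2o1)[C@H](C)c1ccc(-c2cc(F)ccc2-c2nc(=O)o[nH]2)cc1` with 2.7 nM

In a functional assay on CAL1 cells for inhibition of chemerin-like receptor 1 (Homo sapiens), with a stated time of 45 min (a higher number here means a weaker inhibitor, a lower number a stronger inhibitor), compound 2 gives the highest of the three numbers, so it is the weakest inhibitor here; compound 3 lies closer to it and compound 1 furthest, both gaps beyond the scatter.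

The unmeasured compound 4 `CCCCN(c1nc2c(-c3ccccn3)cccc2o1)[C@H](C)c1ccc(-c2ccccc2-c2nnn[nH]2)cc1` is compound 2 with one change: pyridin-2-yl in place of methanesulfonamido on an aromatic carbon.

Going by the values given here, of the one step measured, a 1.2-fold higher number from compound 1 to compound 3 (0.07 log units; within the scatter) concerns the chain carbon on the nitrogen and has no bearing on a change at an aromatic carbon of the fused ring system. Compounds 1 and 3 carry a carboxylic acid at that carbon but also a different terminal ring, so their values against compound 2 show only that the set of two changes lowers the number; they give no isolated reading of the position. Nothing in hand therefore sizes or directs this step in this assay; the estimate leans on the spread of the three numbers alone.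

For compound 4 the expected value is 25 nM with a range from 5 nM to 120 nM, which means an expected step of a 1.8-fold higher number from compound 2 to compound 4 (0.25 log units; within the scatter) and is held wide for want of a guiding step.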

Compound 4, half-maximal inhibitory concentration: 110 nM
Estimate against measurement, compound 4: 4.4-fold (0.64 log units) below, and the stated range covers the measured number.
By their numbers in this assay, from the lowest: compounds 1 and 3 (each within the scatter of the next); then compound 2; then compound 4.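

Going by these compounds alone, the step of a 7.9-fold higher number from compound 2 to compound 4 (0.90 log units; beyond the scatter) in this assay gives the first reading of this aromatic carbon with only one place changed, since the earlier compounds that differ here also carry a different terminal ring. The number at this position therefore moves with the substituent alone, and pyridin-2-yl sits on the weaker side of methanesulfonamido. The change swaps a chain-free sulfonamide group holding a hydrogen-bond donor for an aromatic ring with none, but no measurement in hand accounts for the rise in the number.

Within the data shown here, the single step cannot separate the loss of the donor from the arrival of the ring. An amine or an acetamido group at this aromatic carbon, with the rest of compound 2 kept, would show whether a small donor-bearing group holds the number near that of compound 2.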